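The source may report more compounds than this note shows. Statements on the series, on what has been measured and on what is new or still open speak of the compounds shown alone.

Three analogues sharing one core have been measured in an assay on SH-SY5Y cells for inhibition of Voltage-dependent N-type calcium channel subunit alpha-1B (Homo sapiens), read by FLIPR and calcium flux, with stated times of 600 s and 300 s, in the presence of a further agent that is not named here; on this read-out lower numbers stand for stronger inhibition and higher numbers for weaker inhibition. Compound 1 `CN(Cc1ccc(OCCCN)cc1)c1nc2ccc(Oc3ccc(F)cc3)cc2s1` gives 98000 nM. Compound 2 `NCCCOc1ccc(CNc2nc3ccc(Oc4cccc(C(F)(F)F)c4)cc3s2)cc1` gives 144000 nM. Compound 3 `NCCCOc1ccc(CNc2nc3ccc(Oc4ccc(C(F)(F)F)cc4)cc3s2)cc1` gives 59000 nM, the lowest of the three numbers; against compound 1 the gap lies within the scatter, so the two cannot be ordered, while against compound 2 the gap is beyond the scatter and is recorded as a 2.4-fold lower number from compound 2 to compound 3 (0.39 log units; beyond the scatter).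

The step now followed leads from compound 3 to compound 4 `NCCCOc1ccc(CNc2nc3ccc(Oc4ccc(F)cc4)cc3s2)cc1`. The change is fluoro in place of trifluoromethyl on an aromatic carbon. Going by the values given here, only one measured step exists in this set, the one from compound 2 to compound 3, and it concerns where the trifluoromethyl sits rather than its exchange for fluoro, so it bears on the present step only loosely. Among the compounds with values here, compound 1 carries the 4-fluorophenoxy that compound 4 will carry, but it differs from compound 3 in a second place as well, so no clean step can be drawn from it; its value and that of compound 3 merely fall within the scatter of one another. On this footing no step beyond the scatter is expected in this assay. Compound 4 is therefore expected to give about 80000 nM, within a range of 35000 nM to 180000 nM, which means an estimated step of a 1.4-fold higher number from compound 3 to compound 4 (0.13 log units; within the scatter).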

Compound 4, half-maximal inhibitory concentration: 106000 nM
The estimate for compound 4 lay 1.3-fold (0.12 log units) below the measured number; low and high end bracket the measured number.
By their numbers in this assay, from the lowest: compounds 3, 1, 4 and 2 (each within the scatter of the next, the first and the last beyond it).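

In this assay, fluoro in place of trifluoromethyl on this aromatic carbon, para to a large group, gives a 1.8-fold higher number from compound 3 to compound 4 (0.25 log units; within the scatter) and so stays within the scatter, which means that the one heavy atom of fluoro and the four of trifluoromethyl cannot be told apart here. The earlier gap beyond the scatter thus belongs to the pair of trifluoromethyl isomers alone, since the step of 4-fluorophenyl in place of 3-(trifluoromethyl)phenyl is a 1.4-fold lower number from compound 2 to compound 4 (0.13 log units; within the scatter) and leaves those two compounds unordered. Going by these compounds alone, compound 4 also gives the first clean reading at the nitrogen on the aromatic ring, where hydrogen in place of methyl amounts to a 1.1-fold higher number from compound 1 to compound 4 (0.03 log units; within the scatter) and likewise shows no change that can be read, and nothing measured here offers an explanation for any of these steps.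

The compounds shown leave open whether a chloro, a methoxy or a nitrile on this carbon of the phenoxy group would produce a step beyond the scatter. They also leave open whether a carboxylic acid in place of the terminal amine, or a longer chain carrying that amine, would move the number further than any step seen so far.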